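From One Fluorine to Two on the Carbonyl-Linked Ring

This account rests on a few compounds, and the source may have more. Where it says the series, first, only, none or still open, it means among the compounds named here.

For the measured compounds named here, compound 2 `CN1CCN(c2cccc(N/C=C3\C(=O)Nc4ccc(NC(=O)c5cccc(F)c5)cc43)c2)CC1` gives 6720 nM in a functional assay on HepG2 cells (Homo sapiens) for inhibition, read by sulforhodamine B assay, with a stated time of 3 days (a higher number here means a weaker inhibitor, a lower number a stronger inhibitor), the highest of the two numbers measured so far; its nearest neighbour, compound 1 `COc1ccc(C(=O)Nc2ccc3c(c2)/C(=C/Nc2cccc(N4CCN(C)CC4)c2)C(=O)N3)cc1`, gives 1780 nM. Going by the values given here, the single measured step, a 3.8-fold higher number from compound 1 to compound 2 (0.58 log units; beyond the scatter), changed the substitution of the very ring that now changes again, and it left compound 2 at the weaker end of the pair. Compound 3 `CN1CCN(c2cccc(N/C=C3\C(=O)Nc4ccc(NC(=O)c5c(F)cccc5F)cc43)c2)CC1` differs from compound 2 as follows: 2,6-difluorophenyl in place of 3-fluorophenyl on a carbonyl carbon. Among the compounds with values here, no measured pair shows this particular difference; the step from compound 1 to compound 2 only indicates that swapping substituents on this ring moved the number by a modest amount. With nothing closer to lean on, the analyst expects only a small shift for compound 3 in this assay, a 1.2-fold higher number from compound 2 to compound 3 (0.08 log units; within the scatter), with either direction possible. Her estimate for compound 3 is 8000 nM, within 3000 nM to 25000 nM.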

Compound 3, half-maximal inhibitory concentration: 3030 nM
The estimate for compound 3 lay 2.6-fold (0.42 log units) above the measured number, and the stated range covers the measured number.
By their numbers in this assay, from the lowest: compounds 1 and 3 (each within the scatter of the next); then compound 2.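

In this assay the second step on this ring, a 2.2-fold lower number from compound 2 to compound 3 (0.35 log units; beyond the scatter), shows that this carbonyl carbon accepts 2,6-difluorophenyl and that a fluorinated ring here need not stay at the weaker number of compound 2. Against the 4-methoxyphenyl group, the change gives a 1.7-fold higher number from compound 1 to compound 3 (0.23 log units; within the scatter) and stays within the scatter, so these two differently substituted rings cannot be told apart in this measurement. Nothing on hand accounts for either step.

The step from compound 2 to compound 3 changes the number of fluorines and their placement together, and the compounds shown do not separate the two. Going by these compounds, what a plain phenyl group, or a ring carrying an amine or a carboxylic acid, would give on this carbonyl carbon also stays open.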